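A few compounds are considered here, and "the series" means these few. Any claim that something is new, unique, unknown or untested is made for them only; others in the source may bear on it.

Among the measured compounds shown here, in an ADME assay on MT4 cells (Homo sapiens) for cytotoxicity (on this read-out lower numbers stand for higher toxicity in this test and higher numbers for lower toxicity in this test), the two compounds measured so far give limits and not numbers. Compound 1 `Cc1cc(C)cc(S(=O)(=O)n2c(SCC(=O)Nc3ccccc3[N+](=O)[O-])nc3ccccc32)c1` gives >= 26000 nM, which is a limit of the assay. Compound 2 `Cc1cc(C)cc(S(=O)(=O)n2c(SCC(=O)Nc3ccccc3[N+](=O)[O-])nc3ccc(Cl)cc32)c1` gives > 235000 nM, which is also a limit. Compound 2 therefore stands only at the limit of > 235000 nM in this assay, at which 1 of the 2 values shown sits, with no exact value to start from.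

For the measured compounds named here, the one measured step is a step that the two limits leave unreadable from compound 1 to compound 2, made by chloro in place of hydrogen on an aromatic carbon, so it offers no size to carry forward. Compound 3 `Cc1cc(C)cc(S(=O)(=O)n2c(SCC(=O)Nc3ccc(C)cc3Cl)nc3ccc(Cl)cc32)c1` brings a different change: 2-chloro-4-methylphenyl in place of 2-nitrophenyl on an amide-type nitrogen. Going by the values given here, no measured step touches this group, so the data give no direct guide to its effect.

Compound 2 has only a limit, so a number for compound 3 would be expected to fall under that limit, although another limit is also quite possible. The estimated change is an at least 3.3-fold lower number from compound 2 to compound 3 (0.52 log units; beyond the scatter), a loose expectation towards a lower number. For compound 3 the expected value is 70000 nM, with an estimated range from 12000 nM to 235000 nM.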

Compound 3, half-maximal cytotoxic concentration: > 234000 nM
Compound 3: no number, only a limit; the forecaster's own chance of this, stated with the estimate: 60%; at least 3.3-fold (0.52 log units) between middle value and limit.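

Compound 2 and compound 3 both give only limits and not numbers, so the change from 2-nitrophenyl to 2-chloro-4-methylphenyl between them cannot be read as a step of any size. The compounds shown leave open the actual half-maximal cytotoxic concentration of each compound, and whether either structural change shifts it at all.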